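The compounds below may be only part of what the source reports. "The series", "measured", "known", "first", "only" and "open" are said of these compounds alone.

Three compounds have been run through an ADME assay for permeability, using PAMPA, with a stated time of 30 min, at pH 7.4 (on this read-out lower numbers stand for lower permeability and higher numbers for higher permeability), and a fourth is waiting for its number.

Compound 2, `COc1ccc(Oc2ccc3c(NCCCNCc4cc(F)ccc4OC)ccnc3c2)cc1`, gives 317 10^-6 cm/s in this assay. Compound 1, `COc1ccc(F)cc1CNCCCNc1ccnc2cc(Cc3ccc(C#N)cc3)ccc12`, gives 23 10^-6 cm/s in this assay and differs from compound 2 only on one aromatic carbon of the shared core; the counted difference is 4-cyanobenzyl in place of 4-methoxyphenoxy on an aromatic carbon. With that single change the number falls: a 14-fold lower number from compound 2 to compound 1 (1.14 log units; beyond the scatter). Compound 3, `COc1ccc(Oc2ccc3c(NCCCNCc4ccco4)ccnc3c2)cc1`, carries the same core substituent as compound 2 but a different group on the saturated chain carbon bound to the amine nitrogen, the counted difference being (furan-2-yl in place of 5-fluoro-2-methoxyphenyl on a saturated chain carbon bound to an amine nitrogen). Here the number stays put: no change at the digits printed from compound 2 to compound 3 (within the scatter), and compound 3 gives 317 10^-6 cm/s in this assay.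

Compound 4, `N#Cc1ccc(Cc2ccc3c(NCCCNCc4ccco4)ccnc3c2)cc1`, has not yet been measured. It stands to compound 3 as compound 1 stands to compound 2: the counted difference is 4-cyanobenzyl in place of 4-methoxyphenoxy on an aromatic carbon, and both "place" descriptions read the same, so this is the same change made a second time. The two cores, those of compound 3 and compound 2, differ by furan-2-yl in place of 5-fluoro-2-methoxyphenyl on a saturated chain carbon bound to an amine nitrogen.

Because the earlier instance of this change gave a 14-fold lower number from compound 2 to compound 1 (1.14 log units; beyond the scatter), the step from compound 3 to compound 4 is expected to be of a similar size, a 13-fold lower number from compound 3 to compound 4 (1.10 log units; beyond the scatter). Starting from compound 3, compound 4 is therefore estimated to give about 25 10^-6 cm/s in this assay, most likely falling between 8 10^-6 cm/s and 80 10^-6 cm/s.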

Compound 4, apparent permeability: 23 10^-6 cm/s
For compound 4 the middle estimate is 1.1-fold (0.04 log units) above the measured one, within the range that was stated.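

In this assay, putting 4-cyanobenzyl in place of 4-methoxyphenoxy on the core of compound 3 gives a 14-fold lower number from compound 3 to compound 4 (1.14 log units; beyond the scatter), and this second instance of the change matches the first: the same change on two cores in this assay, a 14-fold lower number (1.14 log units; beyond the scatter) from compound 2 to compound 1 and a 14-fold lower number (1.14 log units; beyond the scatter) from compound 3 to compound 4, 1.0-fold (0.00 log units) apart, within the scatter of two such steps. The other change, furan-2-yl in place of 5-fluoro-2-methoxyphenyl, gives no change at the digits printed from compound 1 to compound 4 (within the scatter) on the cores that carry 4-cyanobenzyl, so across these four compounds the effect of each change on the read-out is the same whichever form of the other group is present: the same change on two cores in this assay, no change at the digits printed (within the scatter) from compound 2 to compound 3 and no change at the digits printed (within the scatter) from compound 1 to compound 4, 1.0-fold (0.00 log units) apart, within the scatter of two such steps. This shows that the large fall carried over between two cores that differ in a single group, but it does not show that it would carry to a core with any other group in that place, and it does not explain why the number falls.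

The compounds shown leave open which part of the exchange goes with the fall, since 4-cyanobenzyl and 4-methoxyphenoxy differ both in the atom that joins them to the core and in the group on their ring, and 4-cyanophenoxy or 4-methoxybenzyl would pull those two apart. They also leave open whether the same step would appear with a longer chain in place of the shared one, or with a cyclohexyl group in place of furan-2-yl.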